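The source may report more compounds than this note shows. Statements on the series, on what has been measured and on what is new or still open speak of the compounds shown alone.

Measured so far in an ADME assay on Raji cells (Homo sapiens) for cytotoxicity, read by CellTiter-Glo and resazurin assay, with a stated time of 72 h; a lower number here means that less compound is needed, a higher number that more compound is needed for the effect:

Compound 1, `CC(C)N(Cc1cccc(OCCCCCC(=O)O)c1)C(=O)c1ccc(-c2cccc(N(C)C)c2)cc1`, gives > 26000 nM, which is a limit of the assay.
Compound 2, `CC(=O)Nc1cccc(-c2ccc(C(=O)N(Cc3cccc(OCCCCCC(=O)O)c3)C(C)C)cc2)c1`, gives > 26000 nM, again a limit of the assay.
Compound 3, `Cc1nnc(-c2cccc(-c3ccc(C(=O)N(Cc4cccc(OCCCCCC(=O)O)c4)C(C)C)cc3)c2)o1`, gives > 26000 nM, also a limit of the assay and not a number.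

Compound 3 therefore stands where every compound in this set stands: at the limit, as the limit of > 26000 nM in this assay, at which 3 of the 3 values shown sit, records. The two changes that lead to it, a step that the two limits leave unreadable from compound 1 to compound 3 and a step that the two limits leave unreadable from compound 2 to compound 3, cannot be sized, and the same holds for a step that the two limits leave unreadable from compound 1 to compound 2. Among the compounds with values here, none of the measured steps shows a direction; they only show that none of the three compounds reached a readable value.

Compound 4, `CC(C)N(Cc1cccc(OCCCCCC(=O)O)c1)C(=O)c1ccc(-c2cccc(C(F)(F)F)c2)cc1`, is the next one to be measured in this assay. It differs from compound 3 as follows: trifluoromethyl in place of 5-methyl-1,3,4-oxadiazol-2-yl on an aromatic carbon. Within the data shown here, no measured step bears on this particular replacement, and the steps that exist are all unreadable, so there is no ground to expect a readable change in either direction beyond the scatter. The expectation is that compound 4 will again sit at or beyond the limit, with a step that the limit leaves unreadable from compound 3 to compound 4 as the step this implies. The estimate for compound 4 is 40000 nM, with a range from 15000 nM to 120000 nM.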

Compound 4, half-maximal effective concentration: > 26000 nM
Compound 4: a limit, no number; the forecaster's own chance of this, stated with the estimate: 85%; the middle value lies beyond the limit too.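

In this assay compound 4 gives > 26000 nM, which is a limit of the assay and not a number. Its steps from compound 1, compound 2 and compound 3 therefore cannot be read, and no new step emerges: the limit of > 26000 nM in this assay, at which 4 of the 4 values shown sit.

The compounds shown leave open which group on this aromatic carbon, if any, would give a readable value in this assay.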